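A few compounds are considered here, and "the series" means these few. Any claim that something is new, unique, unknown or untested is made for them only; others in the source may bear on it.

- compound 1 `COc1cc(C)nc(OC)c1NC(=O)N(Cc1ccc(Oc2ccc(F)cc2)cc1)C1CCCCCC1`: 4.5 mg/kg
- compound 2 `CSc1nc(C)cc(Cl)c1NC(=O)N(Cc1ccc(Oc2ccc(F)cc2)cc1)C1CCCCCC1`: > 1 mg/kg
- compound 3 `Cc1cc(S(C)(=O)=O)c(NC(=O)N(Cc2ccc(Oc3ccc(F)cc3)cc2)C2CCCCCC2)c(Cl)n1`: > 1 mg/kg

In a functional assay on the whole organism with Rattus norvegicus as the target (a higher number here means that more compound is needed for the effect, a lower number that less compound is needed), only compound 1 has a true number. Compound 2 gives only a limit, > 1 mg/kg. Compound 3 also gives only a limit, > 1 mg/kg, so its place on the scale is open.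

Compound 4 `CSc1cc(C)nc(C)c1NC(=O)N(Cc1ccc(Oc2ccc(F)cc2)cc1)C1CCCCCC1` brings this change: a group of 10 heavy atoms (8 carbon, 1 nitrogen, 1 sulfur; one six-membered aromatic ring with 1 hetero atom) in place of a group of 12 heavy atoms (7 carbon, 1 nitrogen, 2 oxygen, 1 sulfur, 1 chlorine; one six-membered aromatic ring with 1 hetero atom), on an amide-type nitrogen.

The measured steps that bear on it, a step that the limit leaves unreadable from compound 1 to compound 3 and a step that the two limits leave unreadable from compound 2 to compound 3, have no readable size, so they suggest no direction. The expectation rests on compound 1 at 4.5 mg/kg, the only firm anchor. The expected step is loose: a step that the limit leaves unreadable from compound 3 to compound 4. The estimate for compound 4 is 3 mg/kg, with an expected range from 0.8 mg/kg to 10 mg/kg.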

Compound 4, dose for half-maximal effect: < 1 mg/kg
Compound 4: no number, only a limit; the forecaster's own chance of this, stated with the estimate: 50%; middle value at least 3.0-fold (0.47 log units) from the limit.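

In this assay, for the compounds shown here, swapping the group on the amide-type nitrogen gives an at least 4.5-fold lower number from compound 1 to compound 4 (0.65 log units; beyond the scatter) as the one step that can be read. Compound 4 has only a limit and no true number: the limit of < 1 mg/kg in this assay, at which 1 of the 4 values shown sits. The steps of a number no higher from compound 2 to compound 4 (the limit leaves the size open) and a number no higher from compound 3 to compound 4 (the limit leaves the size open) cannot be read.

How far compound 4 lies past its limit remains open, as does which part of the swapped group accounts for the step. Also open, as far as these compounds go, is how an amine or a carboxylic acid on that aromatic ring would behave.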